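Adding a Methyl Group to a Fatty Acid Receptor Agonist

The source may report more compounds than this note shows. Statements on the series, on what has been measured and on what is new or still open speak of the compounds shown alone.

Three compounds sharing a thiazolidinedione-bearing core were measured in a functional assay for agonist activity at Free fatty acid receptor 1 (Homo sapiens), read by FLIPR, in the presence of a further agent that is not named here; a higher number here means that more compound is needed for the effect, a lower number that less compound is needed. Compound 1 `O=C1NC(=O)C(Cc2ccc(Oc3ccccc3)cc2)S1` gives 307 nM in this assay. Compound 3 `Cc1ccc(Oc2ccc(CC3SC(=O)NC3=O)cc2)cc1` differs from compound 1 by methyl in place of hydrogen on an aromatic carbon. In this assay compound 3 gives 547 nM, a step of a 1.8-fold higher number from compound 1 to compound 3 (0.25 log units; within the scatter). Compound 2 `O=C1NC(=O)C(Cc2ccc(Oc3ncc(C(F)(F)F)cc3Cl)cc2)S1` gives 69 nM; the difference between its core and that of compound 1 is not broken down here. Compound 2 has the lowest number of the three, and its gaps to compound 1 and compound 3 both lie beyond the scatter.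

Compound 4 `Cc1cc(Oc2ncc(C(F)(F)F)cc2Cl)ccc1CC1SC(=O)NC1=O` has not yet been measured. It differs from compound 2 by methyl in place of hydrogen on an aromatic carbon. Going by the values given here, this is the same kind of change as the one from compound 1 to compound 3, but not the same: there the methyl enters para to a large group, whereas here it enters ortho to a (2,4-dioxo-1,3-thiazolidin-5-yl)methyl group and meta to a large group.

Among the compounds with values here, because the only measured instance of this change, a 1.8-fold higher number from compound 1 to compound 3 (0.25 log units; within the scatter), stayed within the scatter, the step from compound 2 to compound 4 is expected to be modest, about a 1.6-fold higher number from compound 2 to compound 4 (0.20 log units; within the scatter) in this assay. Compound 4 is therefore estimated to give 110 nM in this assay, with a likely range from 40 nM to 320 nM.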

Compound 4, half-maximal effective concentration: 10 nM
Compound 4: middle estimate off by 11-fold (1.04 log units), on the high side; the whole stated range lies above it.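

In this assay, methyl in place of hydrogen on an aromatic carbon gave a clear gain on the core of compound 2, with a 6.9-fold lower number from compound 2 to compound 4 (0.84 log units; beyond the scatter), whereas the same kind of change on the core of compound 1 stayed within the scatter. Set side by side, the two instances do not agree, so the size of this step cannot be assumed to carry from one core to the other in this series: the same change on two cores in this assay, a 1.8-fold higher number (0.25 log units; within the scatter) from compound 1 to compound 3 and a 6.9-fold lower number (0.84 log units; beyond the scatter) from compound 2 to compound 4, 12-fold (1.09 log units) apart, beyond the scatter of two such steps

What this does not show is the reason for the gap, since the two instances differ in both core and place: in compound 4 the methyl stands ortho to a (2,4-dioxo-1,3-thiazolidin-5-yl)methyl group and meta to a large group, while in compound 3 it stands elsewhere, and a single pair on each core cannot separate these two differences.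

The compounds shown leave open whether a methyl group at the place it holds in compound 4 would give a step of this size on the core of compound 1, which would tell place from core. They also leave open whether an ethyl group, a chlorine atom or a methoxy group at that same place would behave as the methyl group does.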